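Chloro to iodo on compound 2: working notes

The source may report more compounds than this note shows. Statements on the series, on what has been measured and on what is new or still open speak of the compounds shown alone.

compound 1 `C/C(=N\NC(=S)Nc1ccccc1I)c1ccccn1` gives 4.1 nM
compound 2 `C/C(=N\NC(=S)Nc1ccc(Cl)cc1)c1ccccn1` gives 8.49 nM
compound 3 `CC(=NNC(=S)Nc1ccccc1F)c1ccccn1` gives 0.39 nM

In a functional assay on MCF7 cells (Homo sapiens) for cytotoxicity, read by MTT assay, with a stated time of 48 h (a lower number here means a stronger inhibitor, a higher number a weaker inhibitor), compound 2 gives 8.49 nM as the highest number of the three. Compound 1 stands nearest to it and compound 3 furthest, both lower by more than the usual scatter. Next comes compound 4 `C/C(=N\NC(=S)Nc1ccc(I)cc1)c1ccccn1` with iodo in place of chloro on an aromatic carbon as its difference: iodo in place of chloro on an aromatic carbon. Among the compounds with values here, no measured pair isolates this exchange. Compound 1, also an iodo compound, gives 4.1 nM but differs from compound 2 in more than this one place, so it is weak guidance. No change beyond the scatter is expected, the estimated step being a 1.4-fold lower number from compound 2 to compound 4 (0.15 log units; within the scatter) overall. For compound 4 the estimated value is 6 nM with a range from 1.5 nM to 25 nM in the same read-out.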

Compound 4, half-maximal inhibitory concentration: 6.61 nM
Beside the measured number, compound 4's estimate is 1.1-fold (0.04 log units) below it; low and high end bracket the measured number.
By their numbers in this assay, from the lowest: compound 3; then compounds 1, 4 and 2 (each within the scatter of the next, the first and the last beyond it).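

In this assay, within the data shown here, the exchange of chloro for iodo gives a 1.3-fold lower number from compound 2 to compound 4 (0.11 log units; within the scatter) and is the first step that changes one place only. On this aromatic carbon, para to a large group, the two halogens therefore cannot be told apart. Nothing available explains this result.

From the compounds shown here alone, whether an amine or a carboxylic acid at this place would move the number remains open. Also open, going by these compounds, is whether the same exchange would stay within the scatter elsewhere on the ring.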